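From hydroxy to methoxy: a step that begins at the limit

The compounds below may be only part of what the source reports. "The series", "measured", "known", "first", "only" and "open" are said of these compounds alone.

Compound 1 `O=C(Nc1ccc(Sc2nc3ccccc3s2)c(Cl)c1)c1ccccc1O` in an assay for inhibition of HSP60/HSP10 (Homo sapiens), with a stated time of 60 min (on this read-out lower numbers stand for stronger inhibition and higher numbers for weaker inhibition), gives > 100000 nM, a limit of the assay rather than a number.
Compound 2 `O=C(Nc1ccc(Sc2nc3ccccc3s2)cc1)c1ccccc1O` in this assay gives > 100000 nM, also a limit.
Compound 3 `COc1c(Br)cccc1C(=O)Nc1cccc(Cl)c1` in this assay gives > 100000 nM, again a limit.

Compound 1 stands at the limit of > 100000 nM in this assay, at which 3 of the 3 values shown sit; every measured value sits there, so no order among the three can be read. Among the measured compounds shown here, the only step measured between compounds that differ in one place, a step that the two limits leave unreadable from compound 1 to compound 2, exchanges hydrogen for chloro on an aromatic carbon, and its size cannot be read from the two limits.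

Compound 4 `COc1ccccc1C(=O)Nc1ccc(Sc2nc3ccccc3s2)c(Cl)c1` is not yet measured. It differs from compound 1 by methyl in place of hydrogen on an oxygen on an aromatic ring, the same difference cut one bond further out reading hydroxy to methoxy, 2-hydroxyphenyl to 2-methoxyphenyl. For the measured compounds named here, no measured step touches this oxygen, so no measured size bears directly on the change. Going by the values given here, compound 3 also carries a methoxy group on an aromatic ring and sits at the limit, but no step links it to compound 1 or to compound 4.

Starting from a limit, compound 4 is expected to give 100000 nM in this assay, most likely again reported only as a limit, with a plausible range from 30000 nM to 300000 nM. The step of a number no higher from compound 1 to compound 4 (the limit leaves the size open) is therefore expected to be unreadable rather than a gain beyond the scatter.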

Compound 4, half-maximal inhibitory concentration: > 100000 nM
Compound 4 gave a limit, no number (the forecaster's own chance of this, stated with the estimate: 85%); the middle value lies on the limit itself.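

In this assay compound 4 gives > 100000 nM, which is a limit of the assay and not a number. The step between compound 1 and compound 4 therefore cannot be read, and no value separates any of the compounds: the limit of > 100000 nM in this assay, at which 4 of the 4 values shown sit.

The compounds shown leave open which change to the shared core, if any, would yield a measurable value.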